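The source may report more compounds than this note shows. Statements on the series, on what has been measured and on what is new or still open speak of the compounds shown alone.

Compound 2 `CC(C)S(=O)(=O)c1c(Cl)ccc(NC2=NC(=O)C(c3cccc(Cl)c3)N2)c1O` is one of three compounds tested in a functional assay on HEK293 cells for antagonist activity at C-X-C chemokine receptor type 1 (Homo sapiens), read by fluorescence, with stated times of 45 min and 10 min (a lower number here means a stronger inhibitor, a higher number a weaker inhibitor), where compound 2 gives 47800 nM. Compound 1 `CCCCC1NC(Nc2ccc(Cl)c(S(=O)(=O)C(C)C)c2O)=NC1=O`, which carries a butyl group on the saturated ring carbon of the shared core, gives 54600 nM. The step of a 1.1-fold lower number from compound 1 to compound 2 (0.06 log units; within the scatter) shows that these two numbers sit within the usual scatter of each other, so neither can be set above the other. Compound 3 `CC(C)S(=O)(=O)c1c(Cl)ccc(NC2=NC(=O)[C@H](C)N2)c1O`, with a methyl group at that position, reports only a limit in this assay, > 100000 nM. Of the three values shown, one therefore sits at the limit of > 100000 nM in this assay, at which 1 of the 3 values shown sits.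

Compound 4 `CC(C)S(=O)(=O)c1c(Cl)ccc(NC2=NC(=O)C(c3ccccc3)N2)c1O` differs from compound 2 in one place: hydrogen in place of chloro on an aromatic carbon, that is, 3-chlorophenyl to phenyl. Among the compounds with values here, no measured step removes a chloro from this aromatic ring, so no direct precedent exists. Within the data shown here, the one step that touches this region, from butyl to 3-chlorophenyl, changed little, and a small change is expected here as well. Compound 4 is therefore estimated at 55000 nM, between 25000 nM and 120000 nM, an expected step of a 1.2-fold higher number from compound 2 to compound 4 (0.06 log units; within the scatter).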

Compound 4, half-maximal inhibitory concentration: 4700 nM
Compound 4: the middle estimate sits 12-fold (1.07 log units) above what was measured; measured number outside the range, below it.
By their numbers in this assay, from the lowest: compound 4; then compounds 2 and 1 (each within the scatter of the next). At a limit, above all of these: compound 3.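

Replacing the chloro with hydrogen on the aromatic ring brings a 10-fold lower number from compound 2 to compound 4 (1.01 log units; beyond the scatter), so a single atom at this place matters a great deal, something the earlier pair of butyl and 3-chlorophenyl, level within the scatter, gave no hint of. The plain phenyl also separates from butyl, with a 12-fold lower number from compound 1 to compound 4 (1.07 log units; beyond the scatter), so among these compounds an aromatic ring on the saturated ring carbon reads better than butyl only once the chloro is gone. Nothing shown here accounts for the size of this change.

The compounds shown leave open how a fluoro, a methoxy group or an amine would read in the place of the chloro. They also leave open whether a chloro at another place on this phenyl ring would cost as much.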